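The source may hold more compounds than are shown below. What is called first, only, known or untested is meant among the compounds shown, and "the series" means these compounds.

Measured so far in a functional assay on MDA-MB-231 cells (Homo sapiens) for inhibition, read by MTT assay, with a stated time of 24 h, tested at 100 uM; a higher number here means more inhibition at the concentration tested (going by the name of the read-out), a lower number less inhibition:
- compound 1 `O=C(N/N=C/c1ccc(F)cc1)c1ccc(O[C@@H]2O[C@H](CO)[C@@H](O)[C@H](O)[C@H]2O)cc1`: 9.91%
- compound 2 `O=C(N/N=C/c1ccc([N+](=O)[O-])cc1)c1ccc(O[C@@H]2O[C@H](CO)[C@@H](O)[C@H](O)[C@H]2O)cc1`: 7.12%

Within the data shown here, both numbers are small, and compound 2 lies within the scatter of compound 1: the step of a number 2.8 percentage points lower from compound 1 to compound 2 (within the scatter) is the only measured step and it does not separate the two compounds. Neither compound shows more than marginal inhibition at the tested concentration.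

Compound 3 `Cc1ccc(/C=N/NC(=O)c2ccc(O[C@@H]3O[C@H](CO)[C@@H](O)[C@H](O)[C@H]3O)cc2)cc1` differs from compound 2 at one place: methyl in place of nitro on an aromatic carbon. Among the measured compounds shown here, the one step measured so far, nitro in place of fluoro on the same aromatic carbon, changed the read-out in this assay by a number 2.8 percentage points lower from compound 1 to compound 2 (within the scatter), i.e. not beyond the scatter. For the measured compounds named here, no other measured pair bears on the methyl substituent, so there is no direct precedent for this change. Given that the one substituent swap already tried at this position left the read-out flat, the step of a number 1.9 percentage points higher from compound 2 to compound 3 (within the scatter) is expected to stay within the scatter as well, with no clear direction. Compound 3 is therefore estimated at 9%, with a plausible range from 1% to 19%.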

Compound 3, a percentage reported as inhibition, at one concentration (the size of the read-out at that concentration, not a potency): 9.28%
The estimate for compound 3 lay 0.3 percentage points below the measured number, and the stated range covers the measured number.
By their numbers in this assay, from the lowest: compounds 2, 3 and 1 (each within the scatter of the next).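

In this assay, the aromatic carbon para to a large group now carries a third substituent, and exchanging nitro, with 2 hydrogen-bond acceptors, for methyl, with 0, gives a number 2.2 percentage points higher from compound 2 to compound 3 (within the scatter) at this position. Methyl in place of fluoro gives a number 0.6 percentage points lower from compound 1 to compound 3 (within the scatter) and so also stays flat, which means that all three substituents shown, including a lone carbon group with no heteroatoms, fall within the scatter of one another and no compound in the set goes against this. No measurement available here accounts for this flat read-out.

On these data alone, all three numbers remain marginal at the single concentration tested, so it remains open whether any group at this carbon can bring the series clearly above that level. An amine, a carboxylic acid or a longer chain in this place would test that question, and the compounds shown say nothing about changes elsewhere on the shared core.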